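The source may hold more compounds than are shown below. What is called first, only, known or untested is meant among the compounds shown, and "the series" means these compounds.

The series shares the core of compound 1 `OC(CCn1nc2c(Br)c(Br)c(Br)c(Br)c2n1)c1cccc(Br)c1`, which in a functional assay on CCRF-CEM cells (Homo sapiens) for antiproliferative activity, read by MTT assay, with a stated time of 24 h, tested at 100 uM (a lower number here means a stronger effect, a higher number a weaker effect of the compound at the concentration tested), compound 1 gives 0%. Among the compounds with values here, compound 2 `OC(CCn1nc2c(Br)c(Br)c(Br)c(Br)c2n1)c1cccc(Cl)c1` gives 0% in this assay, and the only step between measured compounds that differ in one place, no change at the digits printed from compound 1 to compound 2 (within the scatter), follows a chloro in place of bromo on an aromatic carbon. Compound 3 `C[C@@H](O)CCn1nc2c(Br)c(Br)c(Br)c(Br)c2n1` gives 36% in this assay and stands highest of the three numbers, with compound 1 and compound 2 both lying beyond the scatter below it.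

Compound 4 `CC(O)CCn1nc2c(Br)c(Br)c(Br)c(Br)c2n1` has not yet been measured in this assay. (the two compounds have the same atoms and bonds; at least one stereo element is drawn with a configuration in one of them and without one in the other: 1 of 1 stereo elements differ; a stereocentre at a saturated chain carbon is drawn R in compound 3 and without a configuration in compound 4). Within the data shown here, no measured step bears on a stereocentre; the single step available concerns an aromatic substituent and offers no guide here. With the atoms and bonds unchanged, the step of a number 6 percentage points lower from compound 3 to compound 4 (within the scatter) is expected to stay within or only slightly beyond the scatter. Because compound 3 gives 36%, compound 4 is expected to show 30%, in a range from 15% to 45%.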

Compound 4, a percentage reported as activity, at one concentration (the size of the read-out at that concentration, not a potency): 3%
Estimate against measurement, compound 4: 27 percentage points above; the whole stated range lies above it.
By their numbers in this assay, from the lowest: compounds 1, 2 and 4 (each within the scatter of the next); then compound 3.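

In this assay, the stereocentre at the saturated chain carbon now proves to matter: with atoms and bonds unchanged, the pair shows a number 33 percentage points lower from compound 3 to compound 4 (beyond the scatter), the first step among these compounds to go beyond the scatter. With no configuration drawn at that carbon, methyl in place of 3-chlorophenyl gives a number 3 percentage points higher from compound 2 to compound 4 (within the scatter) and methyl in place of 3-bromophenyl gives a number 3 percentage points higher from compound 1 to compound 4 (within the scatter), so neither exchange separates these compounds in this read-out. The large step therefore rests on a single structural difference: the fact that one of compounds 3 and 4 is drawn with a defined configuration and the other without, at the place where they differ

Going by these compounds, it remains open how the opposite configuration at this carbon would read, and what the drawn form of compound 4 contains. Also open, on these data alone, is whether an amine in place of the hydroxyl, or a longer chain, would leave the reading unchanged.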